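The compounds below may be only part of what the source reports. "The series", "measured", "known", "first", "only" and "open" are said of these compounds alone.

Compound 1 `CN1C[C@H]2C=C(c3cccnc3)C[C@H](C2)C1` gives 534 nM in an in vitro assay on SH-SY5Y cells for displacement of a labelled ligand from Neuronal acetylcholine receptor; alpha3/beta4 (Homo sapiens); on this read-out higher numbers stand for weaker inhibition and lower numbers for stronger inhibition. Compound 2 `C1=C(c2cccnc2)C[C@H]2CNC[C@@H]1C2` gives 4 nM. Compound 3 `C1=C(c2cnccn2)CC2CNCC1C2` gives 828 nM.

Among these three, compound 2 stands lowest in this assay, and both other compounds lie beyond the scatter above it. For the measured compounds named here, the only step between compounds differing in a single place is a 130-fold lower number from compound 1 to compound 2 (2.13 log units; beyond the scatter), which concerns a methyl on the ring nitrogen and not the spatial arrangement.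

Compound 4 `C1=C(c2cccnc2)CC2CNCC1C2` differs from compound 2 only in how it is drawn: the two compounds have the same atoms and bonds; at least one stereo element is drawn with a configuration in one of them and without one in the other: 2 of 2 stereo elements differ; a stereocentre at a saturated ring carbon is drawn S in compound 2 and without a configuration in compound 4; a stereocentre at a saturated ring carbon is drawn R in compound 2 and without a configuration in compound 4. Going by the values given here, no measured step touches such a change, so there is nothing to scale an expectation from. Compound 4 may simply contain the form of compound 2, so a small upward shift at most is expected, a 2.0-fold higher number from compound 2 to compound 4 (0.30 log units; within the scatter). Compound 4 is therefore estimated at 8 nM, with a range from 3 nM to 30 nM.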

Compound 4, inhibition constant: 12 nM
Estimate against measurement, compound 4: 1.5-fold (0.18 log units) below; low and high end bracket the measured number.
By their numbers in this assay, from the lowest: compound 2; then compound 4; then compounds 1 and 3 (each within the scatter of the next).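

In this assay there is a 3.0-fold higher number from compound 2 to compound 4 (0.48 log units; beyond the scatter) with no atom or bond changed, so the way these two saturated ring carbons are drawn goes with a real, if modest, shift. This step is much smaller than the one for the methyl on the ring nitrogen. The structures offer only one difference to account for it: the fact that one of compounds 2 and 4 is drawn with a defined configuration and the other without, at the place where they differ.

Which forms compound 4 contains, and in what proportions, remains open, as does the value of the mirror-image form of compound 2. Also open, from the compounds shown here alone, is how an ethyl on that ring nitrogen would compare.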